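From 2-cyanophenyl to 3-fluorophenyl on the shared core

A few compounds are considered here, and "the series" means these few. Any claim that something is new, unique, unknown or untested is made for them only; others in the source may bear on it.

In an ADME assay on brain (Rattus norvegicus) for protein binding (a lower number here means a smaller unbound share, a higher number a larger unbound share of the compound), compound 1 (`N#Cc1ccccc1COc1ccc([C@H]2CC[C@@H](C(N)=O)N2)cc1`) gives 0.063 as the higher of two measured numbers. Compound 2 (`NC(=O)[C@@H]1CC[C@H](c2ccc(OCc3ccccc3F)cc2F)N1`) gives 0.009 and so sits lower, by a gap beyond the usual scatter. Compound 3 (`NC(=O)[C@@H]1CC[C@H](c2ccc(OCc3cccc(F)c3)cc2)N1`) has not yet been measured. Compared with compound 1, it carries 3-fluorophenyl in place of 2-cyanophenyl on a saturated chain carbon bound to an oxygen on an aromatic ring. Going by the values given here, no measured pair of compounds differs in one place only, so the data offer no direct guide to the size of this step. The nearest hint is compound 2 at 0.009 for a structure that also has no nitrile, although it differs from compound 3 in more than one place. On that single comparison a drop is expected in this assay and the estimated change is a 3.2-fold lower number from compound 1 to compound 3 (0.50 log units; beyond the scatter) with the fall expected to lie beyond the scatter. For compound 3 the expected value is 0.02 within an estimated range from 0.009 to 0.045 in this measurement.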

Compound 3, unbound fraction: 0.01
Beside the measured number, compound 3's estimate is 2.0-fold (0.30 log units) above it, and the stated range covers the measured number.
By their numbers in this assay, from the lowest: compounds 2 and 3 (each within the scatter of the next); then compound 1.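

In this assay, putting 3-fluorophenyl in place of 2-cyanophenyl on a saturated chain carbon bound to an oxygen on an aromatic ring gives a 6.3-fold lower number from compound 1 to compound 3 (0.80 log units; beyond the scatter). This is the first step shown that changes one place only, and it shows that the unbound fraction in this assay responds to the group carried at this position even with the shared core left untouched. The exchange removes the nitrile and brings in a fluorine together, and compound 3 arrives at 0.01, so the higher number of compound 1 goes with the 2-cyanophenyl group in this one pair, while nothing shown gives a reason for the size of the step.

This single step cannot separate the loss of the nitrile from the gain of the fluorine, nor the kind of substituent from where it stands on the phenyl ring. As far as these compounds go, a plain phenyl or a 3-cyanophenyl group at the same place would divide those contributions, and whether a ring bearing an amine or a carboxylic acid would carry a larger unbound fraction than compound 1 remains open.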